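A New Group on the Carbonyl Carbon

The compounds below may be only part of what the source reports. "The series", "measured", "known", "first", "only" and "open" are said of these compounds alone.

Three measured compounds share one core and differ only in the group attached to a carbonyl carbon. Compound 1 `Cc1nc(S(C)(=O)=O)ccc1Oc1ncnc(OC2CCN(C(=O)OC3CCC3)CC2)c1F` carries a cyclobutyloxy there, compound 2 `Cc1nc(S(C)(=O)=O)ccc1Oc1ncnc(OC2CCN(C(=O)O[C@@H](C)C(F)(F)F)CC2)c1F` a 1-(trifluoromethyl)ethoxy, and compound 3 `Cc1nc(S(C)(=O)=O)ccc1Oc1ncnc(OC2CCN(C(=O)SC3CCC3)CC2)c1F` a cyclobutylsulfanyl. In a functional assay on isolated protein for inhibition of Glucose-dependent insulinotropic receptor (Rattus norvegicus), read by HTRF and cAMP accumulation (on this read-out higher numbers stand for larger maximal responses and lower numbers for smaller maximal responses), compound 1 gives 81%, compound 2 gives 80%, and compound 3 gives 81%. Compound 2 has the lowest of the three numbers, but its neighbours sit so close that nothing separates them: the step is a number 1 percentage points lower from compound 1 to compound 2 (within the scatter), and a number 1 percentage points higher from compound 2 to compound 3 (within the scatter); between the other two it is no change at the digits printed from compound 1 to compound 3 (within the scatter).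

Compound 4 `Cc1nc(S(C)(=O)=O)ccc1Oc1ncnc(OC2CCN(C(=O)c3noc(C(C)C)n3)CC2)c1F` keeps the whole of compound 2 except at this carbonyl carbon, where (5-isopropyl-1,2,4-oxadiazol-3-yl in place of 1-(trifluoromethyl)ethoxy on a carbonyl carbon). The three measured steps all touch the same position and all stay within the scatter, so among these three compounds the maximal response does not seem to depend on what hangs on this carbon. None of them, however, brings in an aromatic ring, so the new group reaches beyond what the measured steps cover. The expectation is therefore a number 2 percentage points lower from compound 2 to compound 4 (within the scatter), a step not beyond the scatter, with a wider band of uncertainty. Compound 4 is expected to give 78%, within 62% to 92%.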

Compound 4, largest response reached (reported as efficacy), in percent of the reference or control that the assay uses: 81%
Compound 4: middle estimate off by 3 percentage points, on the low side; the range from low to high includes it.
By their numbers in this assay, from the lowest: compounds 2, 1, 3 and 4 (each within the scatter of the next).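

The aromatic ring at this carbonyl carbon gives a reading that cannot be told apart from the others in this assay (a number 1 percentage points higher from compound 2 to compound 4 (within the scatter); no change at the digits printed from compound 3 to compound 4 (within the scatter); no change at the digits printed from compound 1 to compound 4 (within the scatter)). The earlier compounds shown here covered only groups joined to the carbonyl carbon through oxygen or sulfur, whereas 5-isopropyl-1,2,4-oxadiazol-3-yl extends the same picture to a five-membered aromatic ring with 3 hetero atoms, with 3 hydrogen-bond acceptors in place of 1 and no defined stereocentre. No measurement here explains why such different groups give readings that cannot be separated.

Going by these compounds, it remains open whether the same holds for a phenyl ring, a piperazine, or a carboxylic acid at the end of a longer chain on this carbonyl carbon. These numbers also describe only the largest response reached, so they do not tell how much of each compound is needed to reach it.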